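Nitrophenyl for methoxyphenyl on a triazole nitrogen

This account rests on a few compounds, and the source may have more. Where it says the series, first, only, none or still open, it means among the compounds named here.

Compound 1 `O=c1ccc2cc(OCc3cc(-c4cccc([N+](=O)[O-])c4)no3)ccc2o1`: 48300 nM
Compound 2 `COc1ccc(-n2cc(COc3ccc4oc(=O)ccc4c3)nn2)cc1`: 32800 nM

Of the compounds shown here, two have been measured in a functional assay on COLO 205 cells (Homo sapiens) for cytotoxicity, read by MTT assay, with a stated time of 48 h; a lower number here means a stronger inhibitor, a higher number a weaker inhibitor. Compound 2 has the lowest of the two numbers, and in this assay compound 2 gives 32800 nM. Its nearest neighbour is compound 1, which in this assay gives 48300 nM; the gap between the two lies within the scatter, so neither can be called the stronger.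

Compound 3 `O=c1ccc2cc(OCc3cn(-c4cccc([N+](=O)[O-])c4)nn3)ccc2o1` is not yet measured. It differs from compound 2 in one place: 3-nitrophenyl in place of 4-methoxyphenyl on an aromatic nitrogen. Among the compounds with values here, no step between measured compounds shows the effect of this exchange on the shared core. What the data do show is that compound 1, which also carries a 3-nitrophenyl, gives a value close to that of compound 2. On that basis the step of a 1.2-fold higher number from compound 2 to compound 3 (0.09 log units; within the scatter) is expected to be small, in no particular direction, and probably not beyond the scatter. For compound 3 in this assay the estimate is 40000 nM, with a range from 15000 nM to 100000 nM.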

Compound 3, half-maximal inhibitory concentration: 36600 nM
Estimate against measurement, compound 3: 1.1-fold (0.04 log units) above, and the stated range covers the measured number.
By their numbers in this assay, from the lowest: compounds 2, 3 and 1 (each within the scatter of the next).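

The exchange of 4-methoxyphenyl for 3-nitrophenyl on an aromatic nitrogen can now be read directly on the shared core: in this assay it gives a 1.1-fold higher number from compound 2 to compound 3 (0.05 log units; within the scatter). The two groups differ in their substituent, in where it sits on the phenyl ring and in their counts of heavy atoms and hydrogen-bond acceptors, yet this assay cannot tell them apart at this position. Nothing given here explains why these two groups read alike.

Because the substituent and its place on the ring differ together in this single step, the compounds shown cannot separate the effect of one from the other, and a 3-methoxyphenyl or a 4-nitrophenyl group would be needed to pull them apart. As far as these compounds go, it also remains open whether this position would give a reading beyond the scatter with a group of another kind, such as an unsubstituted phenyl, a benzyl, an amine or a carboxylic acid on the phenyl ring, or a longer chain in place of the ring.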